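The source may hold more compounds than are shown below. What is called first, only, known or untested is meant among the compounds shown, and "the series" means these compounds.

Working notes on the shared core of compound 1 `COc1cc2c(Nc3cc(C(F)(F)F)ccc3F)ncnc2c(OC)c1OC`, compound 3 `COc1cc2c(Nc3ccc(B(O)O)cc3)ncnc2c(OC)c1OC` and compound 2 `COc1cc2c(Nc3ccc(Cl)cc3F)ncnc2c(OC)c1OC`, all read in a functional assay on SGC-7901 cells (Homo sapiens) for antiproliferative activity, read by MTT assay, with a stated time of 72 h; a lower number here means a stronger inhibitor, a higher number a weaker inhibitor. Compound 1 gives 10300 nM and compound 3 gives 434 nM. For compound 2 only a limit of this assay is recorded, > 30000 nM; this is the limit of > 30000 nM in this assay, at which 1 of the 3 values shown sits, and no number beyond it is known for compound 2. The next analogue, compound 4 `COc1cc2c(Nc3cccc(Br)c3F)ncnc2c(OC)c1OC`, carries 3-bromo-2-fluorophenyl in place of 4-chloro-2-fluorophenyl on a nitrogen on an aromatic ring. For the measured compounds named here, no step between measured compounds of this kind is at hand, so the size of the move to compound 4 is open; a gain of modest size is expected, since compound 1 with another halogenated aniline gives 10300 nM rather than a limit. Compound 4 is estimated at 15000 nM, within 4000 nM to 50000 nM, an expected at least 2.0-fold lower number from compound 2 to compound 4 (0.30 log units; that floor lies within the scatter).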

Compound 4, half-maximal inhibitory concentration: > 30000 nM
Compound 4 ended at the assay's limit; the forecaster's own chance of this, stated with the estimate: 30%; at least 2.0-fold (0.30 log units) between middle value and limit.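

For the compounds shown here, compound 2 and compound 4 both end at a limit, so no step between them can be read: the limit of > 30000 nM in this assay, at which 2 of the 4 values shown sit. The compounds shown leave open what number either compound would give, and whether 3-bromo-2-fluorophenyl and 4-chloro-2-fluorophenyl differ at all.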